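This account rests on a few compounds, and the source may have more. Where it says the series, first, only, none or still open, it means among the compounds named here.

The measured compounds:
- compound 1 `COc1ccc(/C=C2\S/C(=N\c3ccc(C(C)(C)C)cc3)N(C)C2=O)cc1`: in an ADME assay on TERT-RPE1 cells (Homo sapiens) for cytotoxicity, read by MTT assay, with a stated time of 72 h (a higher number here means a weaker inhibitor, a lower number a stronger inhibitor), compound 1 gives 46700 nM.
- compound 2 `COc1ccc(/C=C2\S/C(=N\c3ccccc3)N(C)C2=O)cc1`: in this assay compound 2 reaches only a limit of the assay, > 100000 nM.
- compound 3 `COc1ccc(/C=C2\S/C(=N\c3ccc(F)cc3)N(C)C2=O)cc1`: in this assay compound 3 likewise reaches only a limit of the assay, > 100000 nM.

Compound 3 therefore stands at the top edge of what this assay can read, together with compound 2; the figure for compound 3 is not a number but the point where measurement stops, (the limit of > 100000 nM in this assay, at which 2 of the 3 values shown sit). Only compound 1 carries a real number. From compound 1 the two readable steps both run upward: an at least 2.1-fold higher number from compound 1 to compound 2 (0.33 log units; beyond the scatter), and an at least 2.1-fold higher number from compound 1 to compound 3 (0.33 log units; beyond the scatter). The comparison of compound 2 with compound 3 is a step that the two limits leave unreadable from compound 2 to compound 3.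

Compound 4 `COc1ccc(/C=C2\S/C(=N\c3ccc(OC)cc3)N(C)C2=O)cc1` differs from compound 3 in one place: methoxy in place of fluoro on an aromatic carbon. Among the compounds with values here, no measured step exchanges these two groups, and no measured pair shows a methoxy at that position, so the only guide is that everything without the tert-butyl sits at the limit. Compound 4 is therefore expected to stay there as well, with a step of a number no higher from compound 3 to compound 4 (the limit leaves the size open) that is essentially none beyond the scatter. The estimated figure for compound 4 in this assay is 100000 nM, within a range from 40000 nM to 250000 nM.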

Compound 4, half-maximal inhibitory concentration: > 100000 nM
Compound 4: a limit, no number; the forecaster's own chance of this, stated with the estimate: 65%; the middle value lies on the limit itself.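

In this assay compound 4 also reaches only a limit of the assay, > 100000 nM, so a methoxy group on this aromatic carbon joins hydrogen and fluoro among the groups that give no number: the limit of > 100000 nM in this assay, at which 3 of the 4 values shown sit.

Within the data shown here, the one new step that can be read is an at least 2.1-fold higher number from compound 1 to compound 4 (0.33 log units; beyond the scatter), which shows that methoxy, like hydrogen and fluoro before it, does not carry over the measurable effect on the cells seen with tert-butyl. The steps among compound 2, compound 3 and compound 4 cannot be read, so no order can be given among these three.

Among the compounds shown, a real number appears only with tert-butyl, and it remains open whether an ethyl or isopropyl group on this carbon would already give a readable value. As far as these compounds go, what an amine or a carboxylic acid would give at this place also remains open.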